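From 3-Methoxyphenyl to 4-Methoxyphenyl: One Step Forward

A few compounds are considered here, and "the series" means these few. Any claim that something is new, unique, unknown or untested is made for them only; others in the source may bear on it.

Three compounds have numbers so far:
in an ADME assay on microsomes from liver (Homo sapiens) for metabolic stability, tested at 2.5 uM (a higher number here means faster removal of the compound, a lower number slower removal), compound 1 `COc1cccc(-c2c(S(=O)(=O)c3ccc(C)c(F)c3)cnc3c(F)cccc23)c1` gives 4.02 mL/min
in this assay compound 2 `O=S(=O)(c1ccc(F)cc1)c1cnc2cc(Cl)c(F)cc2c1-c1ccc(Cl)cc1` gives 0.01 mL/min
in this assay compound 3 `O=S(=O)(c1cc(F)cc(F)c1)c1cnc2c(F)cccc2c1-c1cccc(Cl)c1` gives 0.64 mL/min

Compound 1 stands highest of the three. Its nearest neighbour is compound 3, whose number is lower by a gap beyond the usual scatter, and compound 2 lies far lower still, also beyond the scatter. Among these three, compound 1 is therefore the one removed fastest in this assay.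

Compound 4 `COc1ccc(-c2c(S(=O)(=O)c3ccc(C)c(F)c3)cnc3c(F)cccc23)cc1` has not yet been measured. It differs from compound 1 in one place: 4-methoxyphenyl in place of 3-methoxyphenyl on an aromatic carbon (the two compounds hold the same atoms, joined differently). Going by the values given here, no pair of measured compounds shows this particular change, so no directly comparable step is available. With nothing pointing either way, the expectation for this assay is a step of no more than the usual scatter, in no particular direction. For compound 4 the estimated number is 3.5 mL/min with a range from 1.2 mL/min up to 10 mL/min in this assay. This estimate corresponds to an expected step of a 1.1-fold lower number from compound 1 to compound 4 (0.06 log units; within the scatter) in this assay.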

Compound 4, intrinsic clearance in a liver preparation (reported as CLH), per the amount of preparation that the assay uses: 3.27 mL/min
For compound 4 the middle estimate is 1.1-fold (0.03 log units) above the measured one, within the range that was stated.
By their numbers in this assay, from the lowest: compound 2; then compound 3; then compounds 4 and 1 (each within the scatter of the next).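

Going from 3-methoxyphenyl to 4-methoxyphenyl gives the first comparison in this set that changes only one place in this assay, and the result is a 1.2-fold lower number from compound 1 to compound 4 (0.09 log units; within the scatter), so this change leaves the two compounds indistinguishable in this read-out. Compounds 1, 2 and 3 differ from one another in more than one place, so they could not show what any single change does, whereas this pair isolates one change on an aromatic carbon opposite the ring nitrogen, with the rest of the structure held constant. Nothing measured here bears on why the two compounds behave alike.

On these data alone, this pair covers only these two methoxyphenyl groups on the core of compound 1, so it remains open whether the same change would also leave the number within the scatter on a different core. As far as these compounds go, it also remains open how the number would respond to a larger change at this position, such as an ethoxy group in place of the methoxy group or an amine or a carboxylic acid on the phenyl ring.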